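The compounds below may be only part of what the source reports. "The series", "measured", "known", "first", "only" and "open" are said of these compounds alone.

Of the compounds shown here, two have been tested so far in a functional assay on B16-F10 cells (Mus musculus) for inhibition, read by colorimetric assay and MTT assay, with a stated time of 72 h; on this read-out higher numbers stand for weaker inhibition and lower numbers for stronger inhibition. Compound 1 `COc1ccc(N2CCN(C[C@@H]3C(=O)O[C@H]4[C@H]3C[C@@H](O)/C(C)=C/CC[C@@]3(C)O[C@H]43)CC2)cc1` gives 14000 nM, and compound 2 `C[C@]12O[C@@H]1CC[C@@]1(C)O[C@@H]1[C@H]1OC(=O)[C@@H](CN3CCN(c4ccccc4)CC3)[C@@H]1C[C@H]2O` gives 22000 nM. These two numbers lie within the usual scatter of repeated measurements, so compound 2 stands level with compound 1 on the data available. Compound 3 `C[C@]12O[C@@H]1CC[C@@]1(C)O[C@@H]1[C@H]1OC(=O)[C@@H](CN3CCN(c4ccccc4F)CC3)[C@@H]1C[C@H]2O` differs from compound 2 in one place: fluoro in place of hydrogen on an aromatic carbon, which turns the phenyl into 2-fluorophenyl. Going by the values given here, no measured pair shows what this swap does, so no step beyond the scatter is expected in this assay, in either direction. The estimated step of a 1.1-fold lower number from compound 2 to compound 3 (0.04 log units; within the scatter) is expected to stay within that scatter. The expected value for compound 3 is 20000 nM, with an estimated range from 9000 nM to 42000 nM.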

Compound 3, half-maximal inhibitory concentration: 5000 nM
Beside the measured number, compound 3's estimate is 4.0-fold (0.60 log units) above it; the measured number lies below the stated range.
By their numbers in this assay, from the lowest: compound 3; then compounds 1 and 2 (each within the scatter of the next).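

In this assay, going by these compounds alone, the swap of phenyl to 2-fluorophenyl gives a 4.4-fold lower number from compound 2 to compound 3 (0.64 log units; beyond the scatter) and so stronger inhibition, the first step here that lies beyond the scatter. This shows that the aromatic carbon ortho to a large group is not a silent place: a single added fluoro atom there is enough to change the read-out. Nothing available here explains why the number drops.

On these data alone, whether this step belongs to fluoro in particular, or would also appear with chloro or a methyl group on the same carbon, stays open, as does the effect of fluoro on the other carbons of this ring. One pair also cannot tell whether the same swap would give a similar step on the core of compound 1.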